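This account rests on a few compounds, and the source may have more. Where it says the series, first, only, none or still open, it means among the compounds named here.

Compound 1, `COC(=O)c1nc(C)n(-c2ccccc2)n1`, is the parent of this small series. In a functional assay on NCI-H226 cells (Homo sapiens) for inhibition, read by MTT assay, with a stated time of 72 h (on this read-out lower numbers stand for stronger inhibition of growth and higher numbers for weaker inhibition of growth), compound 1 reaches only the limit > 100000 nM, which is a limit of the assay rather than a number. Compound 2, `COC(=O)c1nc(C)n(-c2ccc(Cl)cc2)n1`, gives 84000 nM in this assay, a change of an at least 1.1-fold lower number from compound 1 to compound 2 (0.07 log units; that floor lies within the scatter). Compound 3, `COC(=O)c1nc(C)n(-c2ccc(F)cc2)n1`, gives 11700 nM, the lowest of the two numbers recorded; the steps were an at least 8.5-fold lower number from compound 1 to compound 3 (0.93 log units; beyond the scatter) and a 7.2-fold lower number from compound 2 to compound 3 (0.86 log units; beyond the scatter).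

Compound 4, `COC(=O)c1nc(C2CC2)n(-c2ccc(F)cc2)n1`, differs from compound 3 by cyclopropyl in place of methyl on an aromatic carbon. For the measured compounds named here, none of the measured steps bears on this change: each of them altered the group on the phenyl ring, whereas here the group on the five-membered aromatic ring with three nitrogens is exchanged. Going by the values given here, with no measured precedent, the expected step from compound 3 to compound 4 in this assay is a 1.2-fold lower number from compound 3 to compound 4 (0.07 log units; within the scatter), which is not one beyond the usual scatter. Compound 4 is therefore estimated at 10000 nM, with a range from 2500 nM to 40000 nM.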

Compound 4, concentration for 50% growth inhibition: 16300 nM
Beside the measured number, compound 4's estimate is 1.6-fold (0.21 log units) below it; measured number inside the range.
By their numbers in this assay, from the lowest: compounds 3 and 4 (each within the scatter of the next); then compound 2. At a limit, above all of these: compound 1.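

Cyclopropyl in place of methyl, on the aromatic carbon between two ring nitrogen atoms, gives a 1.4-fold higher number from compound 3 to compound 4 (0.14 log units; within the scatter) in this assay, so this first measured change at this position does not separate the two compounds. The position thus takes a group of 3 heavy atoms with a three-membered ring in place of 1 heavy atom without a shift beyond the scatter, whereas the earlier step of fluoro in place of chloro, elsewhere in the molecule, gave a 7.2-fold lower number from compound 2 to compound 3 (0.86 log units; beyond the scatter). Nothing among the data shown bears on why this step is so small.

What an amine or a longer chain would do at this position remains open, since only methyl and cyclopropyl are shown there. Also open, as far as these compounds go, is whether the same exchange would read alike in the compounds with chloro or hydrogen in place of fluoro.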